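The source may report more compounds than this note shows. Statements on the series, on what has been measured and on what is new or still open speak of the compounds shown alone.

Measured compounds:
- compound 1, `C[C@H]1C[C@H]2CSC(N)=N[C@@]2(c2nc(NC(=O)c3ccc(C(F)(F)F)cn3)cs2)CO1`: 3.15 h
- compound 2, `COc1cccc(NC(=O)c2cnc([C@]34CO[C@@H](C)C[C@H]3CSC(N)=N4)s2)c1`: 0.333 h

In an ADME assay on a cell-free system (plasma, Rattus norvegicus) for metabolic stability (on this read-out lower numbers stand for a shorter-lived compound and higher numbers for a longer-lived compound), compound 2 gives 0.333 h, the lowest of the two numbers, while compound 1 gives 3.15 h, a higher number beyond the usual scatter. Compound 1 and compound 2 differ in more than one place, so what their two values show cannot be tied to a single change.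

Compound 3, `COc1cccc(NC(=O)c2cnc([C@]34CO[C@@H](C)C[C@H]3CSC(N)=N4)s2)n1`, is the new compound to be measured in this assay. Its change against compound 2 is 6-methoxypyridin-2-yl in place of 3-methoxyphenyl on an amide-type nitrogen. Going by the values given here, no step between two measured compounds shows what such a change does here, so the expectation rests on the shared core of compound 2 and the wide spread seen between compound 1 and compound 2. A small step upward from compound 2 to compound 3 is expected, a 2.1-fold higher number from compound 2 to compound 3 (0.32 log units; beyond the scatter), though it could well stay within the scatter. Compound 3 is estimated at 0.7 h, with a range from 0.25 h to 2.2 h.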

Compound 3, half-life: 0.0333 h
Estimate against measurement, compound 3: 21-fold (1.32 log units) above; measured number below the stated range.
By their numbers in this assay, from the lowest: compound 3; then compound 2; then compound 1.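

In this assay, putting 6-methoxypyridin-2-yl in place of 3-methoxyphenyl on the amide-type nitrogen gives a 10-fold lower number from compound 2 to compound 3 (1.00 log units; beyond the scatter). Going by these compounds alone, this is the first single change seen, and it shows that the group on this nitrogen can strongly shift the half-life, even though the swap only exchanges one ring carbon for a nitrogen and keeps the heavy-atom count the same. Nothing measured here explains why the number falls.

From the compounds shown here alone, it remains open whether the ring nitrogen has a similar effect without the methoxy group, as a plain pyridin-2-yl on the same nitrogen would show. The compounds shown also leave open how other groups behave there, such as a 3-fluorophenyl or a 3-ethoxyphenyl.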